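Removing One Methoxy Group: An Expected Step

A few compounds are considered here, and "the series" means these few. Any claim that something is new, unique, unknown or untested is made for them only; others in the source may bear on it.

In a functional assay on KM12 cells (Homo sapiens) for cytotoxicity, read by sulforhodamine B assay, with a stated time of 48 h, tested at 1 uM (on this read-out lower numbers stand for a stronger effect and higher numbers for a weaker effect at the one concentration tested), compound 1 `COc1cc(-c2cc(/C=C/C(=O)c3ccc(N)cc3)[nH]n2)cc(OC)c1OC` gives 57%. Compound 2 `COc1ccc(C(=O)/C=C/c2cc(-c3cc(OC)c(OC)c(OC)c3)n[nH]2)cc1OC` gives 54% in this assay, and compound 3 `COc1ccc(C(=O)/C=C/c2cc(-c3cc(OC)c(OC)c(OC)c3)n[nH]2)cc1` gives 83%. Between the first two the step is a number 3 percentage points lower from compound 1 to compound 2 (within the scatter), and between compound 1 and compound 3 it is a number 26 percentage points higher from compound 1 to compound 3 (beyond the scatter). The change from compound 2 to compound 3 is hydrogen in place of methoxy on an aromatic carbon, and it made the step of a number 29 percentage points higher from compound 2 to compound 3 (beyond the scatter). Compound 4 `COc1ccc(-c2cc(/C=C/C(=O)c3ccc(N)cc3)[nH]n2)cc1OC` has not yet been measured in this assay. It stands to compound 1 as compound 3 stands to compound 2, the difference being (hydrogen in place of methoxy on an aromatic carbon). The two cores differ by 4-aminophenyl in place of 3,4-dimethoxyphenyl on a carbonyl carbon, and around the place of the change compound 4 is additionally meta to a methoxy group (2 heavy atoms), so this is the same kind of change rather than the same one. Because the earlier step of a number 29 percentage points higher from compound 2 to compound 3 (beyond the scatter) was modest and beyond the scatter, a step of similar size is expected here, a number 25 percentage points higher from compound 1 to compound 4 (beyond the scatter). In this assay compound 4 is therefore expected to give about 82%, estimated to lie between 62% and 98%.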

Compound 4, a percentage reported as activity, at one concentration (the size of the read-out at that concentration, not a potency): 88%
Compound 4: the middle estimate sits 6 percentage points below what was measured, and the stated range covers the measured number.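

In this assay, hydrogen in place of methoxy on an aromatic carbon again came with a clear loss of effect, a number 31 percentage points higher from compound 1 to compound 4 (beyond the scatter). Set beside the earlier case, the change carried over from one core to the other with no difference that the scatter could separate: the same change on two cores in this assay, a number 29 percentage points higher (beyond the scatter) from compound 2 to compound 3 and a number 31 percentage points higher (beyond the scatter) from compound 1 to compound 4, 2 percentage points apart, within the scatter of two such steps This rests on only two pairs, read in one cell line at a single concentration and a single time, so it shows that the step held on these two cores, not that it would hold on any other core or why it has this size.

At this place on the ring, the compounds shown offer only methoxy and hydrogen, so what an ethoxy group, a hydroxyl group or a fluorine atom would give there remains open. Going by these compounds, it also remains open whether the step would keep its size with a different group on the carbonyl side, such as a carboxylic acid in place of the amino group of compound 1.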